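The source may hold more compounds than are shown below. What is called first, only, known or untested is meant among the compounds shown, and "the series" means these compounds.

For the measured compounds named here, in a functional assay on MOLT-4F cells (Homo sapiens) for antiproliferative activity (a higher number here means a weaker inhibitor of growth, a lower number a stronger inhibitor of growth), compound 1 `COCCCCCCCCCCC/C=C1\CC(CO)(COC(=O)C(C)(C)C)OC1=O` gives 2.38 ug/mL, the only actual number so far. Compound 2 `COC(=O)CCCCCCCCCCCCCC/C=C1\CC(CO)(COC(=O)C(C)(C)C)OC1=O` reads > 10 ug/mL, which is a limit of the assay. Going by the values given here, the one measured step, an at least 4.2-fold higher number from compound 1 to compound 2 (0.62 log units; beyond the scatter), lies beyond the scatter, but it replaces methoxy with a much larger group. Compound 3 `CC(C)(C)C(=O)OCC1(CO)C/C(=C\CCCCCCCCCCCO)C(=O)O1` differs from compound 1 by less: hydrogen in place of methyl on an oxygen on a saturated carbon. That step is only a loose guide, so no change beyond the scatter is expected. The expected step is a 1.5-fold higher number from compound 1 to compound 3 (0.17 log units; within the scatter). For compound 3 the estimated value is 3.5 ug/mL, with an expected range from 1.2 ug/mL to 10 ug/mL.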

Compound 3, concentration for 50% growth inhibition: 1.34 ug/mL
Compound 3: middle estimate off by 2.6-fold (0.42 log units), on the high side; measured number inside the range.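

Hydrogen in place of methyl on an oxygen on a saturated carbon gives a 1.8-fold lower number from compound 1 to compound 3 (0.25 log units; within the scatter), so in this assay this change does not move the reading beyond the scatter. Hydroxy in place of 3-(methoxycarbonyl)propyl gives an at least 7.4-fold lower number from compound 2 to compound 3 (0.87 log units; beyond the scatter), a step beyond the scatter. The reading of compound 2 is a limit and not a number: the limit of > 10 ug/mL in this assay, at which 1 of the 3 values shown sits.

From the compounds shown here alone, whether an amine or a carboxylic acid in this place would read like methoxy and hydroxy remains open. The compounds shown also do not separate the longer chain of compound 2 from its methyl ester.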